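Adding a Methoxy Group to Compound 2

The source may report more compounds than this note shows. Statements on the series, on what has been measured and on what is new or still open speak of the compounds shown alone.

Measured in an ADME assay on MT4 cells (Homo sapiens) for cytotoxicity, read by MTT assay, with a stated time of 4 days; on this read-out higher numbers stand for lower toxicity in this test and lower numbers for higher toxicity in this test:
- compound 1 `COc1ccc(-c2oc3ccc(N)cc3c(=O)c2O)cc1`: 239000 nM
- compound 2 `COc1c(-c2ccccc2)oc2ccc(N)cc2c1=O`: 126000 nM

Compound 2, at 126000 nM, lies within the usual scatter of compound 1, at 239000 nM, so the two cannot be told apart. Compound 3 `COc1ccc(-c2oc3ccc(N)cc3c(=O)c2OC)cc1` differs from compound 2 by methoxy in place of hydrogen on an aromatic carbon. Among the measured compounds shown here, no measured pair shows this change, so the expectation is only that this assay moves by no more than the scatter, in neither direction. The step of a 1.2-fold higher number from compound 2 to compound 3 (0.08 log units; within the scatter) is expected to be that small. The estimate for compound 3 is 150000 nM, with an expected range of 70000 nM to 300000 nM.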

Compound 3, half-maximal cytotoxic concentration: 200000 nM
The estimate for compound 3 lay 1.3-fold (0.12 log units) below the measured number, within the range that was stated.
By their numbers in this assay, from the lowest: compounds 2, 3 and 1 (each within the scatter of the next).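

In this assay, among the compounds shown here, methoxy in place of hydrogen on an aromatic carbon gives a first measured step for this change (a 1.6-fold higher number from compound 2 to compound 3 (0.20 log units; within the scatter)), and it lies within the scatter. Methyl in place of hydrogen on an oxygen on an aromatic ring also stays within the scatter (a 1.2-fold lower number from compound 1 to compound 3 (0.08 log units; within the scatter)), so neither swap gives a difference that can be told from noise in these compounds. No measurement shown offers an explanation for these results.

From the compounds shown here alone, whether an amine or a carboxylic acid on that aromatic carbon would give a step beyond the scatter stays open. So does the effect of a longer chain on that oxygen.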